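The source may hold more compounds than are shown below. What is called first, only, known or untested is meant among the compounds shown, and "the series" means these compounds.

Compound 1 `COc1ccc(CCOC(=O)c2oc3cc(-c4ccccc4)cc(O)c3c2C)cc1`: 0.02 ug/mL
Compound 2 `COCc1ccccc1C(=O)c1oc2cc(-c3ccccc3)cc(O)c2c1C`: 0.1 ug/mL

Both compounds were tested in a functional assay on WI-38 VA13 cells (Homo sapiens) for cytotoxicity (a lower number here means that less compound is needed, a higher number that more compound is needed for the effect), which reports how much compound is needed to harm the cells. Compound 1 needs only 0.02 ug/mL, whereas compound 2 needs 0.1 ug/mL. Of the two numbers, compound 2 has the higher one, and the gap to compound 1 lies beyond the scatter of repeated measurements, so compound 2 is the weaker of the two in this assay.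

The compound that has not yet been measured is compound 3 `Cc1c(C(=O)c2ccc(N(C)C)cc2)oc2cc(-c3ccccc3)cc(O)c12`. It is built on the same core as compound 2 and differs in one place: 4-(dimethylamino)phenyl in place of 2-(methoxymethyl)phenyl on a carbonyl carbon. Within the data shown here, because no pair of measured compounds differs in a single place, there is no directly comparable step to lean on, and the two measured compounds differ in more than this one group. With that in mind, the step from compound 2 to compound 3 is expected to be small, no change at the digits printed from compound 2 to compound 3 (within the scatter), probably not beyond the scatter in either direction. Compound 3 is therefore estimated at 0.1 ug/mL, with a plausible range from 0.03 ug/mL to 0.4 ug/mL.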

Compound 3, half-maximal effective concentration: > 4 ug/mL
Compound 3 was reported as a limit; the forecaster's own chance of this, stated with the estimate: 5%; middle value at least 40-fold (1.60 log units) from the limit.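

In this assay, compound 3 is reported only as a limit, > 4 ug/mL. Putting 4-(dimethylamino)phenyl in place of 2-(methoxymethyl)phenyl on a carbonyl carbon gives an at least 40-fold higher number from compound 2 to compound 3 (1.60 log units; beyond the scatter), which shows that the group on this carbonyl carbon can matter a great deal in this assay, even though the two groups have the same number of heavy atoms, the same kind of aromatic ring and the same counts of hydrogen-bond donors and acceptors. The true size of the step stays unknown because the reading for compound 3 stops at a limit, so the printed size is only a minimum: the limit of > 4 ug/mL in this assay, at which 1 of the 3 values shown sits.

The swap changes both the substituent on the ring and the place where it sits, and the compounds shown cannot separate the two; a plain phenyl or a 2-(dimethylamino)phenyl on the same carbonyl carbon would be needed to tell them apart. Compound 1 differs from compound 2 and compound 3 in more than one place, so it cannot show how much of this step comes from the group that changed.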